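Acetylating the Hydroxy Group of Compound 1

The compounds below may be only part of what the source reports. "The series", "measured", "known", "first", "only" and "open" are said of these compounds alone.

Compound 1 (`COCC1=C2/C(=C\[C@@]3(C)CC[C@](O)(O3)[C@@](C)(O)C[C@@H]2O)OC1=O`) was tested for cytotoxicity in a functional assay on HepG2 cells (Homo sapiens) for cytotoxicity; a lower number here means a stronger inhibitor, a higher number a weaker inhibitor. In this assay compound 1 gives > 5 ug/mL, which is a limit of the assay and not a number. Compound 2 (`CC(=O)OCC1=C2/C(=C\[C@@]3(C)CC[C@](O)(O3)[C@@](C)(O)C[C@@H]2O)OC1=O`) gives > 5 ug/mL, and this too is a limit. Neither compound therefore has a numerical position, and the evidence amounts to the limit of > 5 ug/mL in this assay, at which 2 of the 2 values shown sit.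

Compound 3 (`COCC1=C2/C(=C\[C@@]3(C)CC[C@](O)(O3)[C@@](C)(O)C[C@@H]2OC(C)=O)OC1=O`) departs from compound 1 in one place: acetyl in place of hydrogen on an oxygen on a saturated carbon. This is acetyl in place of hydrogen on an oxygen on a saturated carbon, or hydroxy to acetoxy.

Going by the values given here, the only measured step that bears on this change is a step that the two limits leave unreadable from compound 1 to compound 2. It also introduces acetyl, though in place of methyl and at a different oxygen, so it offers no size to carry over. The outcome expected here is a step that the limit leaves unreadable from compound 1 to compound 3, with no firm direction and no clear change beyond the scatter expected. Compound 3 is estimated at 7 ug/mL, with an expected range from 2.5 ug/mL to 20 ug/mL. A limit rather than a number is the more likely report.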

Compound 3, half-maximal inhibitory concentration: > 5 ug/mL
Compound 3 was reported as a limit; the forecaster's own chance of this, stated with the estimate: 70%; the middle value lies beyond the limit too.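

In this assay compound 3 gives > 5 ug/mL, which is a limit of the assay and not a number. Compound 1 also has only a limit, so the step between these two compounds cannot be read. The compounds shown leave open how much acetyl in place of hydrogen changes the value, and where each compound truly stands: the limit of > 5 ug/mL in this assay, at which 3 of the 3 values shown sit.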